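This account rests on a few compounds, and the source may have more. Where it says the series, first, only, none or still open, it means among the compounds named here.

Measured so far in a functional assay on MCF7 cells (Homo sapiens) for antiproliferative activity, read by MTT assay, with a stated time of 48 h; a lower number here means a stronger inhibitor, a higher number a weaker inhibitor:
compound 1 `O=C(Nc1cccc(/C=C/C(=O)c2nc3ccccc3[nH]2)c1)c1cccc(Br)c1` gives 5210 nM
compound 2 `O=C(Nc1cccc(/C=C/C(=O)c2nc3ccccc3[nH]2)c1)c1ccc(Br)cc1` gives 7000 nM

For the measured compounds named here, compound 2 sits at the top of the two measured numbers, but the only step known, a 1.3-fold higher number from compound 1 to compound 2 (0.13 log units; within the scatter), is within the scatter, so compound 1 and compound 2 are indistinguishable in this assay.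

Compound 3 `O=C(Nc1cccc(/C=C/C(=O)c2nc3ccccc3[nH]2)c1)c1cccc(C(F)(F)F)c1` is not yet measured. The change from compound 2 to compound 3 is 3-(trifluoromethyl)phenyl in place of 4-bromophenyl on a carbonyl carbon. Going by the values given here, the one measured step moved bromine from one position to another on the same phenyl ring and did not shift the number beyond the scatter; it bears on the present change only loosely, since here the substituent itself is exchanged. Among the compounds with values here, no measured step speaks to the trifluoromethyl group. The expectation is therefore a step of a 1.3-fold lower number from compound 2 to compound 3 (0.10 log units; within the scatter) of no size beyond the scatter.

Compound 3 is expected to give about 5500 nM, with a likely range from 2000 nM to 15000 nM.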

Compound 3, half-maximal inhibitory concentration: 21500 nM
Estimate against measurement, compound 3: 3.9-fold (0.59 log units) below, and the stated range ends below it.
By their numbers in this assay, from the lowest: compounds 1 and 2 (each within the scatter of the next); then compound 3.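

In this assay, the group on the phenyl ring attached to the carbonyl carbon now matters: trifluoromethyl in place of bromo gives a 4.1-fold higher number from compound 1 to compound 3 (0.62 log units; beyond the scatter), whereas the earlier exchange of 3-bromophenyl for 4-bromophenyl stayed within the scatter. The exchange of 4-bromophenyl for 3-(trifluoromethyl)phenyl points the same way, with a 3.1-fold higher number from compound 2 to compound 3 (0.49 log units; beyond the scatter), so both steps beyond the scatter run toward a weaker inhibitor, and the two bromo compounds stand together on the stronger side of compound 3. No available measurement bears on what lies behind these steps.

Going by these compounds, whether this loss is particular to trifluoromethyl or also appears with other groups on this ring, such as methoxy, nitrile or an amine, remains open. Also open, on these data alone, is how a plain phenyl on the carbonyl carbon would compare with the bromo compounds.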